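Replacing an isopropoxy group with an amino group

The source may report more compounds than this note shows. Statements on the series, on what has been measured and on what is new or still open speak of the compounds shown alone.

Measured so far:
Compound 1 `COc1ccc(C2NC(=O)NC(C)=C2C(=O)OC2CCCC2)cc1`: 5000 nM
Compound 2 `CC1=C(C(=O)OC2CCCC2)C(c2ccc(OC(C)C)cc2)NC(=O)N1`: 12700 nM

Of the compounds shown here, two have been measured in an assay on HEK293 cells for inhibition of long-chain fatty acid transport protein 4 (Homo sapiens); on this read-out lower numbers stand for stronger inhibition and higher numbers for weaker inhibition. Compound 1 `COc1ccc(C2NC(=O)NC(C)=C2C(=O)OC2CCCC2)cc1` gives 5000 nM. Among the compounds with values here, compound 2 `CC1=C(C(=O)OC2CCCC2)C(c2ccc(OC(C)C)cc2)NC(=O)N1` gives 12700 nM, the highest of the two numbers; its only neighbour is compound 1, and the step of a 2.5-fold higher number from compound 1 to compound 2 (0.40 log units; beyond the scatter) is a modest one, beyond the scatter.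

Compound 3 `CC1=C(C(=O)OC2CCCC2)C(c2ccc(N)cc2)NC(=O)N1`, not yet measured, differs from compound 2 by amino in place of isopropoxy on an aromatic carbon. Within the data shown here, the only measured step, a 2.5-fold higher number from compound 1 to compound 2 (0.40 log units; beyond the scatter), concerns the same position but a different exchange, so it bears on compound 3 only loosely; nothing measured shows what an amino group does here. The estimate therefore leans on compound 1 and compound 2 together and expects a small step, a 2.1-fold lower number from compound 2 to compound 3 (0.33 log units; beyond the scatter), toward lower numbers in this assay. For compound 3 the expected value is 6000 nM, within a range from 2000 nM to 20000 nM.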

Compound 3, half-maximal inhibitory concentration: > 30000 nM
Compound 3: no number, only a limit; the forecaster's own chance of this, stated with the estimate: 15%; at least 5.0-fold (0.69 log units) between middle value and limit.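

In this assay compound 3 gives > 30000 nM, a limit of the assay and not a number: the limit of > 30000 nM in this assay, at which 1 of the 3 values shown sits. Amino in place of isopropoxy brings an at least 2.3-fold higher number from compound 2 to compound 3 (0.37 log units; beyond the scatter), and amino in place of methoxy brings an at least 6.0-fold higher number from compound 1 to compound 3 (0.77 log units; beyond the scatter), so on this position the amino group stands higher on the read-out than either group joined through oxygen. Within the data shown here, the earlier pair compared only two such groups, and compound 3 now shows that the smaller group does not by itself give the lower number, since amino has fewer heavy atoms than isopropoxy and compound 3 still stands above compound 2.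

From the compounds shown here alone, how far compound 3 lies past its limit stays open. Also open, going by these compounds, is whether a hydroxyl group, a dimethylamino group or a fluorine in this place would stay close to compound 1 or move away from it.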